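The source may hold more compounds than are shown below. What is called first, only, known or untested is meant among the compounds shown, and "the series" means these compounds.

Of the compounds shown here, two of the same series have been measured in an ADME assay on the whole organism (Macaca fascicularis) for pharmacokinetics, read by LC-MS, using cassette dosing, at a dose of 1 mg/kg by the oral route; on this read-out higher numbers stand for higher exposure at the dose given and lower numbers for lower exposure. Compound 1 `C[C@H](c1ccc(-c2ccccc2-c2nc(=O)o[nH]2)cc1)N(CC1CC1)c1nc2c(C(=O)O)cccc2o1` gives 11600 ng.h/mL. Compound 2 `CCCCN(c1nc2c(C(=O)O)cccc2o1)[C@H](C)c1ccc(-c2cc(F)ccc2-c2nc(=O)o[nH]2)cc1` gives 1630 ng.h/mL, the lower of the two numbers by a margin that lies beyond the usual scatter; since these two compounds differ in more than one place, the gap cannot be tied to any single change. Compound 3 `C[C@H](c1ccc(-c2cc(F)ccc2-c2nc(=O)o[nH]2)cc1)N(CC1CC1)c1nc2c(C(=O)O)cccc2o1` is the next to be measured. It differs from compound 2 in one place: cyclopropyl in place of propyl on a saturated chain carbon bound to a nitrogen on an aromatic ring. Compound 1 carries that same cyclopropylmethyl group and gives 11600 ng.h/mL, the only pointer available, yet compound 1 also differs from compound 3 elsewhere, so the pointer is weak. Compound 3 is therefore expected to show a moderate rise, a 2.5-fold higher number from compound 2 to compound 3 (0.39 log units; beyond the scatter), in this assay. The estimate for compound 3 is 4000 ng.h/mL, within a range from 1500 ng.h/mL to 11000 ng.h/mL.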

Compound 3, area under the concentration-time curve: 4410 ng.h/mL
For compound 3 the middle estimate is 1.1-fold (0.04 log units) below the measured one, and the stated range covers the measured number.
By their numbers in this assay, from the lowest: compound 2; then compound 3; then compound 1.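

In this assay, the cyclopropyl in place of propyl on a saturated chain carbon bound to a nitrogen on an aromatic ring can now be read on its own, giving a 2.7-fold higher number from compound 2 to compound 3 (0.43 log units; beyond the scatter). Compound 3 also separates out the fluoro in place of hydrogen on an aromatic carbon, a change that gives a 2.6-fold lower number from compound 1 to compound 3 (0.42 log units; beyond the scatter), so each change alone produces a modest step beyond the scatter. Nothing available here explains why exposure moves in either step.

Each change has been read only once, against a single partner, so neither step can be assumed to hold on a different background. As far as these compounds go, whether a cyclobutyl on that chain carbon, or a chloro in place of the fluoro, would shift exposure in the same direction remains open.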